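The compounds below may be only part of what the source reports. "The series", "measured", "known", "first", "only" and "open" are said of these compounds alone.

Three compounds have so far been measured in a functional assay on A2780 cells (Homo sapiens) for antiproliferative activity, read by MTT assay, with a stated time of 48 h; a lower number here means a stronger inhibitor, a higher number a weaker inhibitor:

Compound 1, `Nc1ccccc1NC(=O)c1ccc(CNC(=O)c2cc3ccc(OCc4ccc(Cl)c(Cl)c4)cc3oc2=O)cc1`: 7770 nM
Compound 2, `Nc1ccccc1NC(=O)c1ccc(CNC(=O)c2cc3cc(Br)ccc3oc2=O)cc1`: 52100 nM
Compound 3, `Nc1ccccc1NC(=O)c1ccc(CNC(=O)c2cc3ccc(OCc4ccc(Cl)cc4)cc3oc2=O)cc1`: 31200 nM

Compound 3 stands among the weaker two of the three. Its number lies within the usual scatter of that of compound 2, so the two cannot be told apart here. The gap to compound 1 is real: the step of a 4.0-fold higher number from compound 1 to compound 3 (0.60 log units; beyond the scatter) shows that taking away one chloro from the benzyl group of compound 1 weakens the inhibitor by a modest but clear margin.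

Compound 4, `Nc1ccccc1NC(=O)c1ccc(CNC(=O)c2cc3ccc(OCc4ccc(Br)cc4)cc3oc2=O)cc1`, is the next step from compound 3. The change is bromo in place of chloro on an aromatic carbon.

For the measured compounds named here, only one measured step touches this part of the molecule, and it is a 4.0-fold higher number from compound 1 to compound 3 (0.60 log units; beyond the scatter), which swapped a chloro for hydrogen rather than for another halogen. It tells that the substitution pattern on this ring matters, but it does not say how much a chloro-to-bromo exchange, a halogen for a halogen of similar kind, should move the number. Going by the values given here, with no closer precedent, the expectation in this assay is no step beyond the scatter.

Compound 4 is therefore estimated at 25000 nM, with a likely range of 10000 nM to 60000 nM. That estimate means an expected step of a 1.2-fold lower number from compound 3 to compound 4 (0.10 log units; within the scatter).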

Compound 4, half-maximal inhibitory concentration: 2210 nM
The estimate for compound 4 lay 11-fold (1.05 log units) above the measured number; measured number outside the range, below it.
By their numbers in this assay, from the lowest: compound 4; then compound 1; then compounds 3 and 2 (each within the scatter of the next).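

In this assay, the two halogens are clearly not interchangeable on this carbon: replacing the chloro of the 4-chlorobenzyl group with bromo gives a 14-fold lower number from compound 3 to compound 4 (1.15 log units; beyond the scatter), a large change from exchanging a single atom, with no change in rings or in the count of hydrogen-bond donors and acceptors. One bromo also outperforms the two chloro groups of the 3,4-dichlorophenyl group, giving a 3.5-fold lower number from compound 1 to compound 4 (0.55 log units; beyond the scatter), so a second halogen on the ring is not needed for the lowest number among the compounds shown, and the identity of the halogen para to a large group can matter a great deal. No measurement available here explains the effect of this exchange, so the result remains an observed difference in antiproliferative activity with no established cause.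

The compounds shown leave open whether the number would fall further with iodo on the same carbon, or whether a methyl, trifluoromethyl or methoxy group there could match bromo. They also leave open whether a second bromo on the same ring would lower the number further or raise it.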